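This account rests on a few compounds, and the source may have more. Where it says the series, first, only, none or still open, it means among the compounds named here.

Compound 3 `Cc1ccc(CNc2ncc(C(=O)O)c3nc(-c4ccco4)nn23)cc1` has only a limit to its name. In a functional assay on CHO cells for antagonist activity at adenosine receptor A2b (Homo sapiens) (on this read-out higher numbers stand for weaker inhibition and lower numbers for stronger inhibition), compound 3 gives > 10000 nM, which is a limit of the assay rather than a number. Compound 2 `CNc1ncc(C(=O)O)c2nc(-c3ccco3)nn12` gives > 10000 nM, again a limit and not a measured value. Compound 1 `COc1ccc(CNc2ncc(C(=O)O)c3nc(-c4ccco4)nn23)cc1OC` gives > 30000 nM, also a limit of this assay. The step that the two limits leave unreadable from compound 2 to compound 3 therefore cannot be sized. Compound 4 `COc1ccc(CNc2ncc(C(=O)O)c3nc(-c4ccco4)nn23)cc1` differs from compound 3 by methoxy in place of methyl on an aromatic carbon. For the measured compounds named here, no measured step bears directly on this change, the one step in hand being unreadable. Compound 1, which carries two methoxy groups, sits at the limit of > 30000 nM in this assay, at which 1 of the 3 values shown sits. Compound 3 itself sits at the limit of > 10000 nM in this assay, at which 2 of the 3 values shown sit. Since every value shown is a limit, no direction can be read for the change from methyl to methoxy, and compound 4 is expected to stay beyond the reach of this assay as well. The step that the limit leaves unreadable from compound 3 to compound 4 is expected to be no more than scatter. Compound 4 is estimated at 20000 nM, in a range from 5000 nM to 100000 nM.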

Compound 4, inhibition constant: > 30000 nM
Compound 4: a limit, no number (the forecaster's own chance of this, stated with the estimate: 80%); at least 1.5-fold (0.17 log units) between middle value and limit.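

Compound 4 yields only a limit, as do compounds 1, 2 and 3, so its steps to those three compounds cannot be read. The compounds shown leave open what real value any of them has in this assay, and whether methoxy in place of methyl changes it.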